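Adding a methyl group to compound 2

The compounds below may be only part of what the source reports. "The series", "measured", "known", "first", "only" and "open" are said of these compounds alone.

Compound 1 `Brc1ccc2[nH]c(-c3cn(-c4ccccc4)nc3-c3ccccc3)nc2c1` with 1810 nM
Compound 2 `Cc1ccc2[nH]c(-c3cn(-c4ccccc4)nc3-c3ccccc3)nc2c1` with 3610 nM

Within the data shown here, in a functional assay on A549 cells (Homo sapiens) for antiproliferative activity, read by MTT assay, with a stated time of 48 h (on this read-out lower numbers stand for stronger inhibition and higher numbers for weaker inhibition), compound 2 gives 3610 nM and lies within the scatter of its only neighbour, compound 1 (1810 nM). Compound 3 (`Cc1cc2nc(-c3cn(-c4ccccc4)nc3-c3ccccc3)[nH]c2cc1C`) differs from compound 2 by one change (methyl in place of hydrogen on an aromatic carbon): methyl in place of hydrogen on an aromatic carbon, ortho to a methyl group. Among the measured compounds shown here, only one measured step bears on this: a 2.0-fold higher number from compound 1 to compound 2 (0.30 log units; within the scatter), with methyl in place of bromo on an aromatic carbon. For the measured compounds named here, no measured step shows a methyl replacing hydrogen, so the evidence is indirect, and no step beyond the scatter is expected in this assay, in either direction. The estimated step is a 1.1-fold lower number from compound 2 to compound 3 (0.05 log units; within the scatter) and it is expected to stay within the scatter. Compound 3 is expected at 3200 nM, with an estimated range from 1400 nM to 7500 nM as the likely span.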

Compound 3, half-maximal inhibitory concentration: 14500 nM
Beside the measured number, compound 3's estimate is 4.5-fold (0.66 log units) below it; the whole stated range lies below it.
By their numbers in this assay, from the lowest: compounds 1 and 2 (each within the scatter of the next); then compound 3.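

In this assay, adding one methyl ortho to a methyl group gives a 4.0-fold higher number from compound 2 to compound 3 (0.60 log units; beyond the scatter), a change beyond the scatter. Among these compounds, the earlier swap of bromo for methyl, a 2.0-fold higher number from compound 1 to compound 2 (0.30 log units; within the scatter), stayed within the scatter, so only this new step shows that the number on this part of the core can respond to a substituent, and that a group of just 1 heavy atom is enough to move it. No measured evidence here says why the number rises with this change.

The compounds shown leave open whether a methoxy group, a chloro atom or an amine at this carbon would give a number closer to that of compound 2 or to that of compound 3. They also leave open whether the rise depends on the methyl already present, or would also follow from a methyl added ortho to the bromo of compound 1.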